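Adding a Second Methoxy to a Diaryl Thioether Ligand

The source may hold more compounds than are shown below. What is called first, only, known or untested is meant among the compounds shown, and "the series" means these compounds.

Two measured compounds frame this step. Going by the values given here, compound 1, `COc1ccccc1Sc1ccc(NC2=NCCN2)cc1`, and compound 2, `COc1cccc(Sc2ccc(NC3=NCCN3)cc2)c1`, share one core and differ only in where the single methoxy group sits. In an assay (Rattus norvegicus) for binding affinity to prostacyclin receptor (Homo sapiens), read by radioligand binding (a lower number here means a stronger inhibitor, a higher number a weaker inhibitor), compound 1 gives 3980 nM, and compound 2 gives 398 nM. Compound 2 thus holds the lower of the two numbers, and its gap to compound 1 lies beyond the usual scatter. Compound 3, `COc1ccc(OC)c(Sc2ccc(NC3=NCCN3)cc2)c1`, carries one further change relative to compound 2: methoxy in place of hydrogen on an aromatic carbon, on an aromatic carbon ortho to a large group and para to a methoxy group. Among the compounds with values here, no measured pair shows this exact step. A modest weakening is expected for compound 3, the expected step being a 2.3-fold higher number from compound 2 to compound 3 (0.35 log units; beyond the scatter), partly because compound 1 gives 3980 nM in this assay. Compound 3 is therefore estimated at 900 nM, within a range from 250 nM to 3200 nM.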

Compound 3, inhibition constant: 794 nM
Compound 3: middle estimate off by 1.1-fold (0.05 log units), on the high side; the measured number falls inside the stated range.
By their numbers in this assay, from the lowest: compounds 2 and 3 (each within the scatter of the next); then compound 1.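

In this assay a methoxy on an aromatic carbon ortho to a large group and para to a methoxy group is tolerated on top of the methoxy of compound 2: the result is a 2.0-fold higher number from compound 2 to compound 3 (0.30 log units; within the scatter) and so gives no measurable separation between the two compounds. Compound 3 carries the methoxy groups of both compound 1 and compound 2, and seen from the other side the added methoxy gives a 5.0-fold lower number from compound 1 to compound 3 (0.70 log units; beyond the scatter), so the high number of compound 1 does not persist once both groups are present. No independent measurement here bears on why these numbers fall as they do.

On these data alone, whether a hydroxyl, an amine or a longer chain such as propoxy on this carbon would be accepted equally remains open. So does whether a carboxylic acid there would move the number beyond the scatter.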